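This account rests on a few compounds, and the source may have more. Where it says the series, first, only, none or still open, it means among the compounds named here.

Going by the values given here, compound 1 `Cn1c(-c2ccccc2)nc2c(NC3CCCC3)ncnc21` holds the only number among the three compounds measured: in a functional assay on CHO cells for antagonist activity at adenosine receptor A2b (Homo sapiens), read by 33P incorporation, with a stated time of 20 min (on this read-out lower numbers stand for stronger inhibition and higher numbers for weaker inhibition), compound 1 gives 8510 nM. Compound 2 `Cn1c(-c2ccc(C(=O)O)cc2)nc2c(NC3CCCC3)ncnc21` reaches only a limit of this assay, > 30000 nM. Compound 3 `Cc1ccccc1-c1nc2c(NC3CCCC3)ncnc2n1C` likewise reaches only a limit, > 30000 nM. The steps of an at least 3.5-fold higher number from compound 1 to compound 2 (0.54 log units; beyond the scatter) and an at least 3.5-fold higher number from compound 1 to compound 3 (0.54 log units; beyond the scatter) both alter a substituent on an aromatic carbon, and both were at least modest, but neither touches the nitrogen on an aromatic ring. Compound 4 `Cn1c(-c2ccccc2)nc2c(NC3CCC3)ncnc21` differs from compound 1 by cyclobutyl in place of cyclopentyl on a nitrogen on an aromatic ring. Among the compounds with values here, no measured step alters that position, so the expected movement is none beyond the scatter, and compound 4 is expected near 10000 nM, between 4000 nM and 30000 nM. The expected step is a 1.2-fold higher number from compound 1 to compound 4 (0.07 log units; within the scatter).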

Compound 4, inhibition constant: 3730 nM
Compound 4: middle estimate off by 2.7-fold (0.43 log units), on the high side, and the stated range ends above it.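

Cyclobutyl in place of cyclopentyl on a nitrogen on an aromatic ring gives a 2.3-fold lower number from compound 1 to compound 4 (0.36 log units; beyond the scatter) in this assay, so this position, which no earlier step touched, does respond to a change of ring size. This is the only step shown that lowers the number, and the only one with a number at both ends; the two earlier steps end at a limit of the assay: the limit of > 30000 nM in this assay, at which 2 of the 4 values shown sit. As far as these compounds go, whether a still smaller cyclopropyl would lower the number further stays open, as one step sets no trend. So does how an open chain such as isopropyl, or a ring carrying an amine, would read on that nitrogen.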